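The compounds below may be only part of what the source reports. "The series", "measured", "known", "first", "only" and "open" are said of these compounds alone.

In a physicochemical assay for lipophilicity, in phosphate buffer, measured as octanol-water partition, at pH 7.4 (a lower number here means a more polar compound, a higher number a more lipophilic compound), compound 1 `O=C(CN1CCN(c2cccc(F)c2)CC1)Nc1nc2c(s1)CCCC2` has no number to start from, its entry being "not determined" (no result reported) and nothing more. The nearest measured compound is compound 2 `O=C(CN1CCN(c2ccc(F)cc2)CC1)Nc1nc2c(s1)CCCCC2`, which gives 5 and offers the only reference level. The move to compound 3 `O=C(CN1CCN(c2ccccn2)CC1)Nc1nc2c(s1)CCCC2` puts pyridin-2-yl in place of 3-fluorophenyl on an amine nitrogen in a ring, counted as pyridin-2-yl in place of 3-fluorophenyl on an amine nitrogen in a ring with the rest of compound 1 kept. For the measured compounds named here, no measured pair shows this swap, so a clear step down in this assay from that reference level, beyond the usual scatter, is only an expectation. For compound 3 the estimated value is 3.8 with an expected range from 3.2 to 4.4 for the coming measurement.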

Compound 3, distribution coefficient: 3.9
Compound 3: the middle estimate sits 0.10 log units below what was measured; the range from low to high includes it.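

In this assay compound 1 has no number to set against compound 3, so no new step can be read. The compounds shown leave open how far pyridin-2-yl in place of 3-fluorophenyl shifts the value on the shared core. Nothing on hand bears on the result for compound 3.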